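From Fluoro to Chloro in a Pancreatic Cell Growth Assay

The source may report more compounds than this note shows. Statements on the series, on what has been measured and on what is new or still open speak of the compounds shown alone.

Compound 2 `O=C(/C=C\c1cccc(F)c1)N1N=C(c2ccncc2)OC1c1c[nH]c2ccccc12` carries a fluoro group on an aromatic carbon of a six-membered aromatic ring of carbon only, meta to a large group. In an ADME assay on PANC-1 cells (Homo sapiens) for cytotoxicity, read by MTT assay, with a stated time of 48 h (on this read-out higher numbers stand for weaker inhibition of growth and lower numbers for stronger inhibition of growth), compound 2 gives only a limit of > 30 ug/mL. Compound 1 `O=C(/C=C\c1cccc(O)c1)N1N=C(c2ccncc2)OC1c1c[nH]c2ccccc12`, with hydroxy in place of that fluoro, likewise gives a limit of > 30 ug/mL in this assay. The step that the two limits leave unreadable from compound 1 to compound 2 therefore has no readable size, both values sitting at the limit of > 30 ug/mL in this assay, at which 2 of the 2 values shown sit. Compound 3 `O=C(/C=C\c1cccc(Cl)c1)N1N=C(c2ccncc2)OC1c1c[nH]c2ccccc12` differs from compound 2 by chloro in place of fluoro on an aromatic carbon. For the measured compounds named here, no measured step in this assay carries a known size, so nothing bears on this change with a number; the step that the limit leaves unreadable from compound 2 to compound 3 is expected to stay within the scatter. Compound 3 is therefore estimated at 40 ug/mL, within 15 ug/mL to 100 ug/mL, and most likely reported again as a limit.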

Compound 3, concentration for 50% growth inhibition: > 30 ug/mL
Compound 3 was reported as a limit; the forecaster's own chance of this, stated with the estimate: 85%; the middle value is on the limit's open side.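

For the compounds shown here, compound 1, compound 2 and compound 3 are all reported only as limits in this assay, so no step among them can be read: the limit of > 30 ug/mL in this assay, at which 3 of the 3 values shown sit. The compounds shown leave open whether hydroxy, fluoro and chloro differ at all in their inhibition of growth.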